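Removing Bromine in a Paw Edema Inhibition Series

The compounds below may be only part of what the source reports. "The series", "measured", "known", "first", "only" and "open" are said of these compounds alone.

Three compounds were tested in a functional assay on the whole organism (strain Charles-Foster albino) for inhibition, with Rattus norvegicus as the target, read by paw edema, at a dose of 50 mg/kg by the oral route; on this read-out higher numbers stand for more inhibition at the one dose given (going by the name of the read-out) and lower numbers for less inhibition. Compound 1 `COc1ccc(C2SCC(=O)N2n2c(CSc3nnc(-c4ccncc4)o3)nc3ccccc3c2=O)cc1` gives 33.8%. Compound 2 `COc1ccc(C2SCC(=O)N2n2c(CSc3nnc(-c4ccncc4)o3)nc3ccc(Br)cc3c2=O)cc1` gives 35.3%. Compound 3 `O=C1CSC(c2ccc(O)cc2)N1n1c(CSc2nnc(-c3ccncc3)o2)nc2ccc(Br)cc2c1=O` gives 32.7%. Compound 1 differs from compound 2 by hydrogen in place of bromo on an aromatic carbon, and this gave a number 1.5 percentage points lower from compound 2 to compound 1 (within the scatter). Compound 3 differs from compound 2 by hydrogen in place of methyl on an oxygen on an aromatic ring, and this gave a number 2.6 percentage points lower from compound 2 to compound 3 (within the scatter). All three numbers sit within the ordinary scatter of one another, so none can be set apart. Compound 4 `O=C1CSC(c2ccc(O)cc2)N1n1c(CSc2nnc(-c3ccncc3)o2)nc2ccccc2c1=O` has not yet been measured. It differs from compound 3 by hydrogen in place of bromo on an aromatic carbon, the same change, at the same place, as that from compound 2 to compound 1. Because that earlier step was a number 1.5 percentage points lower from compound 2 to compound 1 (within the scatter), the step expected here is a number 1.2 percentage points lower from compound 3 to compound 4 (within the scatter). Compound 4 is estimated at 31.5%, most likely between 22% and 41%.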

Compound 4, a percentage reported as inhibition, in the whole organism at one dose (the size of the read-out at that dose, not a potency): 31.7%
For compound 4 the middle estimate is 0.2 percentage points below the measured one; low and high end bracket the measured number.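

Replacing bromo with hydrogen gave a number 1 percentage points lower from compound 3 to compound 4 (within the scatter), and this agrees with the earlier step on the other core: the same change on two cores in this assay, a number 1.5 percentage points lower (within the scatter) from compound 2 to compound 1 and a number 1 percentage points lower (within the scatter) from compound 3 to compound 4, 0.5 percentage points apart, within the scatter of two such steps

Replacing the methyl on the oxygen with hydrogen gave a number 2.1 percentage points lower from compound 1 to compound 4 (within the scatter), and this change also repeats: the same change on two cores in this assay, a number 2.6 percentage points lower (within the scatter) from compound 2 to compound 3 and a number 2.1 percentage points lower (within the scatter) from compound 1 to compound 4, 0.5 percentage points apart, within the scatter of two such steps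

Among these compounds, each change therefore looks the same on both cores in these four compounds, but since every step lies within the scatter, this shows only that neither change had a detectable effect at this dose, not that either group helps or harms inhibition.

The compounds shown carry only bromo or hydrogen at one place and only methyl or hydrogen on the oxygen at the other. As far as these compounds go, whether an amine, a carboxylic acid or a longer chain at either place would shift the number beyond the scatter remains open.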